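This account rests on a few compounds, and the source may have more. Where it says the series, first, only, none or still open, it means among the compounds named here.

Measured compounds:
- compound 1 `CC1(COc2cccc(-c3ccc(F)nc3)n2)CCn2cc([N+](=O)[O-])nc2O1`: in an ADME assay on MRC5 cells (Homo sapiens) for cytotoxicity, read by resazurin assay, with a stated time of 72 h (a lower number here means a stronger inhibitor, a higher number a weaker inhibitor), compound 1 gives > 64000 nM
- compound 2 `O=[N+]([O-])c1cn2c(n1)OC(COc1cnc(-c3ccc(F)cc3)nc1)CC2`: in this assay compound 2 gives 62000 nM

The value for compound 1 is a limit of the assay, not a number: it only tells that the cells were not harmed at the highest concentration tested, as the limit of > 64000 nM in this assay, at which 1 of the 2 values shown sits, records. Compound 2, which shares the nitroimidazole-bearing core but carries a different attached ring system, gives a measurable number sitting close to that same region, so both compounds show little cytotoxicity on these cells.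

Compound 3 `CC1(COc2cccc(-c3ccc(F)nc3F)n2)CCn2cc([N+](=O)[O-])nc2O1` is a near twin of compound 1. The change is fluoro in place of hydrogen on an aromatic carbon. The extra fluoro sits on the six-membered aromatic ring with one nitrogen, next to the ring nitrogen, ortho to the large group and meta to the fluoro group already present. For the measured compounds named here, there is no measured pair in this set showing what a single added fluoro does in this assay, so no step size can be read off. Given that compound 1 already sits at the limit > 64000 nM, the expectation for compound 3 is a step that the limit leaves unreadable from compound 1 to compound 3, that is, none beyond the scatter. Compound 3 is estimated at 70000 nM, within 30000 nM to 160000 nM, most likely again reported only as a limit.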

Compound 3, half-maximal inhibitory concentration: > 64000 nM
Compound 3 ended at the assay's limit (the forecaster's own chance of this, stated with the estimate: 75%); the middle value is on the limit's open side.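

No step can be read from compound 1 to compound 3, because each of their results in this assay is a limit and not a number: the limit of > 64000 nM in this assay, at which 2 of the 3 values shown sit. The compounds shown leave open what the added fluoro does to these cells, and whether compound 1 and compound 3 differ at all.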